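Swapping a methoxy for two methyls on the distal ring

A few compounds are considered here, and "the series" means these few. Any claim that something is new, unique, unknown or untested is made for them only; others in the source may bear on it.

Compound 1 `Cn1ccnc1[C@@H](CC(=O)O)c1ccc(OCc2cccc(-c3ccccc3S(C)(=O)=O)c2)cc1` gives 23000 nM in an assay on CHO cells for agonist activity at Free fatty acid receptor 1 (Homo sapiens), read by luminescence, with a stated time of 20 s, in the presence of a further agent that is not named here; on this read-out lower numbers stand for an effect already at smaller amounts and higher numbers for an effect only at larger amounts of compound.
Compound 2 `COc1ccccc1-c1cccc(COc2ccc([C@H](CC(=O)O)c3nccn3C)cc2)c1` gives 410 nM in this assay.

Going by the values given here, of these two numbers, compound 2 stands lowest; the one measured step is a 56-fold lower number from compound 1 to compound 2 (1.75 log units; beyond the scatter). Compound 3 `Cc1cccc(C)c1-c1cccc(COc2ccc([C@H](CC(=O)O)c3nccn3C)cc2)c1` differs from compound 2 by 2,6-dimethylphenyl in place of 2-methoxyphenyl on an aromatic carbon. That measured step changed a different substituent on the same ring, so it bears on the present change only loosely, and no step beyond the scatter is expected. Compound 3 is therefore estimated at 300 nM in this assay, within 80 nM to 1200 nM. The expected step is a 1.4-fold lower number from compound 2 to compound 3 (0.14 log units; within the scatter).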

Compound 3, half-maximal effective concentration: 58 nM
Compound 3: the middle estimate sits 5.2-fold (0.71 log units) above what was measured; measured number below the stated range.
By their numbers in this assay, from the lowest: compound 3; then compound 2; then compound 1.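

Replacing 2-methoxyphenyl with 2,6-dimethylphenyl gives a 7.1-fold lower number from compound 2 to compound 3 (0.85 log units; beyond the scatter) in this assay, so this position still has room for improvement after the first step, and the better group here has no hydrogen-bond acceptor. The change from 2-(methylsulfonyl)phenyl to 2,6-dimethylphenyl gives a 400-fold lower number from compound 1 to compound 3 (2.60 log units; beyond the scatter), the widest span among these compounds. Nothing available here accounts for either step. The compounds leave open whether a single methyl group would match the two in compound 3, and how a 2,6-dichlorophenyl or 2-aminophenyl group would read.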